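A ring swap on compound 3, judged against a limit

The compounds below may be only part of what the source reports. "The series", "measured", "known", "first", "only" and "open" are said of these compounds alone.

Three measured compounds share one core, seen in compound 1 `Nc1ncn(CCC2(N)OC(=O)C(OCc3ccccc3)=C2OCc2ccccc2)c(=O)n1`. Its companions are compound 2 `O=C1O/C(=C\Cn2ccc(NC(=O)c3ccccc3)nc2=O)C(OCc2ccccc2)=C1OCc1ccccc1` and compound 3 `NC1(CCn2ncc(=O)[nH]c2=O)OC(=O)C(OCc2ccccc2)=C1OCc1ccccc1`. In a functional assay on HepG2 cells (Homo sapiens) for inhibition, read by MTT assay, with a stated time of 72 h (a lower number here means a stronger inhibitor, a higher number a weaker inhibitor), compound 1 gives only the limit > 100000 nM. In this assay compound 2 gives 1980 nM. Compound 3 gives only the limit > 100000 nM in this assay, so it stands where the assay stops reporting a number. Two of the three values shown share that limit (the limit of > 100000 nM in this assay, at which 2 of the 3 values shown sit).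

For the measured compounds named here, the only step between measured compounds that differ in one place is a step that the two limits leave unreadable from compound 1 to compound 3; because both ends are limits, its size cannot be read.

Compound 4 `NC1(CCn2cc(F)c(=O)[nH]c2=O)OC(=O)C(OCc2ccccc2)=C1OCc1ccccc1` differs from compound 3 by a group of 9 heavy atoms (4 carbon, 2 nitrogen, 2 oxygen, 1 fluorine; one six-membered aromatic ring with 2 hetero atoms) in place of a group of 8 heavy atoms (3 carbon, 3 nitrogen, 2 oxygen; one six-membered aromatic ring with 3 hetero atoms), on a saturated chain carbon, two bonds along the chain from a saturated ring carbon. No measured step bears directly on this change, and the single step that exists is itself unreadable, so nothing shown points either way for compound 4. With compound 3 already at the limit, compound 4 is expected to remain at or near that limit in this assay, the expected step being a number no higher from compound 3 to compound 4 (the limit leaves the size open). The estimate for compound 4 is therefore 100000 nM, with a range from 20000 nM to 300000 nM, and a further limit rather than a number is the likelier outcome.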

Compound 4, half-maximal inhibitory concentration: 42800 nM
Compound 4: the middle estimate sits 2.3-fold (0.37 log units) above what was measured; measured number inside the range.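

For the compounds shown here, at this position, on a saturated chain carbon, two bonds along the chain from a saturated ring carbon, the choice of ring can be read in this assay for the first time. The group with one six-membered aromatic ring with 2 hetero atoms and a fluorine gives an at least 2.3-fold lower number from compound 3 to compound 4 (0.36 log units; beyond the scatter), and set against the group of compound 1 it gives an at least 2.3-fold lower number from compound 1 to compound 4 (0.36 log units; beyond the scatter). Both steps are only lower bounds on the change, because each starts from a compound that the assay reports as a limit and not as a number: the limit of > 100000 nM in this assay, at which 2 of the 4 values shown sit.

The change swaps the ring's hetero atoms and brings in the fluorine in one move, so the compounds shown cannot separate the two, and a chlorine or a methyl group in the fluorine's stead would be needed to test the role of that atom. They also leave open whether a longer chain carrying the same ring would hold, lower or raise the number seen for compound 4, 42800 nM, which remains well short of the value of compound 2, a compound that differs in more than one place.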